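The compounds below may be only part of what the source reports. "The series", "measured", "known", "first", "only" and "open" are said of these compounds alone.

Working notes on the series. Among the compounds with values here, compound 1 `CNC(=O)c1cc(Oc2ccc(NC(=O)c3nccc(-c4ccccc4)n3)cc2)ccn1` in a functional assay on PC-3 cells (Homo sapiens) for cytotoxicity, read by MTT assay, with a stated time of 72 h (on this read-out lower numbers stand for stronger inhibition and higher numbers for weaker inhibition), gives 7310 nM, the lowest of the three numbers measured so far. Compound 3 `CCc1ccc(-c2cc(C(=O)Nc3ccc(Oc4ccnc(C(=O)NC)c4)c(F)c3)ncn2)cc1` in this assay gives 15600 nM, a higher number than compound 1 by a margin beyond the scatter. Compound 2 `CNC(=O)c1cc(Oc2ccc(NC(=O)c3cc(-c4ccc(OC)cc4)ncn3)cc2F)ccn1` in this assay gives 56200 nM, the highest of the three and well beyond the scatter from compound 1. Compound 2 and compound 3 differ in one place only, and there a 3.6-fold lower number from compound 2 to compound 3 (0.56 log units; beyond the scatter).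

Compound 4 `CNC(=O)c1cc(Oc2ccc(NC(=O)c3nccc(-c4ccc(C)cc4)n3)cc2)ccn1` differs from compound 1 at a single point: methyl in place of hydrogen on an aromatic carbon. Within the data shown here, the only measured step that bears on a substituent on this six-membered aromatic ring of carbon only is the one from compound 2 to compound 3, where a larger alkyl in place of methoxy lowered the number modestly. That comparison is ethyl against methoxy rather than methyl against hydrogen, and compounds 2 and 3 also carry a fluorine that compound 1 and compound 4 lack, so it indicates direction more than size. A modest lowering, or no step beyond the scatter, is therefore expected. Compound 4 is expected to give 5000 nM, within a range of 2000 nM to 14000 nM. The expected step is a 1.5-fold lower number from compound 1 to compound 4 (0.16 log units; within the scatter).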

Compound 4, half-maximal inhibitory concentration: 13100 nM
Estimate against measurement, compound 4: 2.6-fold (0.42 log units) below; the range from low to high includes it.
By their numbers in this assay, from the lowest: compounds 1, 4 and 3 (each within the scatter of the next, the first and the last beyond it); then compound 2.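

In this assay, methyl in place of hydrogen on an aromatic carbon of the six-membered aromatic ring of carbon only, para to a large group, gives a 1.8-fold higher number from compound 1 to compound 4 (0.25 log units; within the scatter) and so leaves compound 1 and compound 4 indistinguishable on this read-out. Within the data shown here, this is the first step that starts from an unsubstituted phenyl, and it shows that the phenyl to 4-methylphenyl change on this core carries no effect that can be separated from the scatter, whereas a 3.6-fold lower number from compound 2 to compound 3 (0.56 log units; beyond the scatter) is a step beyond the scatter, though it is a different exchange, ethyl in place of methoxy, on a fluorinated compound. The data shown contain no measurement that could account for either step.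

The compounds shown leave open whether ethyl or methoxy at this place on the core of compound 1, without the fluorine, would repeat the step seen between compound 2 and compound 3. They also leave open whether an amine, a carboxylic acid or a longer chain at this place would give a step beyond the scatter in either direction.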